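The source may hold more compounds than are shown below. What is called first, only, known or untested is meant among the compounds shown, and "the series" means these compounds.

Compound 2 `Cc1cc(Nc2cc(-c3ccc(Cl)cc3)[nH]n2)n2nc(SCc3ccc(Br)cc3)nc2n1` is the reference point here. In a functional assay on PC-9 cells (Homo sapiens) for inhibition, read by MTT assay, with a stated time of 72 h (on this read-out lower numbers stand for stronger inhibition and higher numbers for weaker inhibition), compound 2 gives 4920 nM. Its closest companion is compound 1 `Cc1cc(Nc2ccn(Cc3cccc4ccccc34)n2)n2nc(SCc3ccc(Br)cc3)nc2n1`, which differs in how the side group hangs off the shared core; in this assay compound 1 gives 5660 nM. The two numbers sit within the usual scatter of each other, so they describe the same level of inhibition rather than a difference. Compound 3 `Cc1nc2nc(SCc3ccc(Cl)cc3)nn2c(Nc2cc(-c3ccccc3)[nH]n2)c1C` carries a different core and a different halogen; in this assay compound 3 returns only a limit, > 50000 nM, and not a number (the limit of > 50000 nM in this assay, at which 1 of the 3 values shown sits). Among the compounds with values here, no two measured compounds differ in just one place, so there is no measured step to lean on, and the size of any change has to be judged from the structures alone.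

The unmeasured compound 4 `Cc1cc(Nc2cc(-c3ccccc3)[nH]n2)n2nc(SCc3ccc(Br)cc3)nc2n1` is reached from compound 2 by a single small edit: hydrogen in place of chloro on an aromatic carbon. Removing the chloro takes away one heavy atom and leaves the rest of the molecule untouched. The step expected here, a 1.8-fold higher number from compound 2 to compound 4 (0.26 log units; within the scatter), is a modest weakening, of a size near the edge of the scatter, with no more than that expected. For compound 4 the estimated result in this assay is 9000 nM, expected to fall between 3000 nM and 30000 nM.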

Compound 4, half-maximal inhibitory concentration: 4760 nM
Beside the measured number, compound 4's estimate is 1.9-fold (0.28 log units) above it; the range from low to high includes it.
By their numbers in this assay, from the lowest: compounds 4, 2 and 1 (each within the scatter of the next). At a limit, above all of these: compound 3.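

In this assay, within the data shown here, this pair gives the first measured step between compounds that differ in one place: a 1.0-fold lower number from compound 2 to compound 4 (0.01 log units; within the scatter). Going from 4-chlorophenyl to phenyl therefore leaves the two compounds at the same level of inhibition. The earlier compounds shown here could not give such a result. No two of them differed in just one place. At this position, on an aromatic carbon of a six-membered aromatic ring of carbon only, para to a large group, the chloro is not needed to hold that level, and hydrogen serves equally well in this one pair.

From the compounds shown here alone, only chloro and hydrogen can be compared at this position, so it remains open whether an amine, a methoxy group or a carboxylic acid there would also leave the level of inhibition in place, or whether the same swap would read the same way on a different core. Nothing among the data shown bears on why chloro and hydrogen give the same level of inhibition here.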